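The compounds below may be only part of what the source reports. "The series", "measured", "known", "first", "only" and "open" are said of these compounds alone.

Two compounds of the shared core have been run in an ADME assay on PC-3 cells (Homo sapiens) for cytotoxicity, read by sulforhodamine B assay, with a stated time of 48 h, tested at 10 uM; on this read-out higher numbers stand for more inhibition at the one concentration tested (going by the name of the read-out) and lower numbers for less inhibition. Compound 1 `COc1nc2ccc(Br)cc2cc1C(c1ccccc1)n1cc(-c2ccc(Br)cc2)nn1` gives 7.43%. Compound 2 `COc1nc2ccc(Br)cc2cc1C(c1ccccc1)n1cc(CCCCCO)nn1` gives 12.9%; in this assay compound 2 stands highest of the two numbers, its nearest neighbour being compound 1, and the step of a number 5.5 percentage points higher from compound 1 to compound 2 (within the scatter) lies within the scatter, so the two values show no ordering.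

Compound 3 `CCCCCCCCc1cn(C(c2ccccc2)c2cc3cc(Br)ccc3nc2OC)nn1` is not yet measured in this assay. It differs from compound 2 by propyl in place of hydroxy on a saturated chain carbon, five bonds along the chain from an aromatic carbon. For the measured compounds named here, no measured step touches the chain end in this way; the single step known, from compound 1 to compound 2, exchanges the whole substituent on the aromatic carbon and stays within the scatter. On that basis the expected step of a number 1.1 percentage points higher from compound 2 to compound 3 (within the scatter) is none beyond the scatter. Compound 3 is therefore estimated at 14% in this assay, with a range from 3% to 30%.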

Compound 3, a percentage reported as inhibition, at one concentration (the size of the read-out at that concentration, not a potency): 2.27%
Estimate against measurement, compound 3: 11.7 percentage points above; the whole stated range lies above it.
By their numbers in this assay, from the lowest: compounds 3, 1 and 2 (each within the scatter of the next, the first and the last beyond it).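

For the compounds shown here, the chain end is the first place where a single change moves the number in this assay beyond the scatter: propyl in place of hydroxy gives a number 10.6 percentage points lower from compound 2 to compound 3 (beyond the scatter), although the step is modest. Octyl in place of 4-bromophenyl on the aromatic carbon, by contrast, gives a number 5.2 percentage points lower from compound 1 to compound 3 (within the scatter), so this exchange, like the earlier one at that carbon, shows no ordering. No measured evidence shown here bears on this result.

The step from hydroxy to propyl removes the hydroxy and extends the chain together, so the compounds shown do not separate these two changes. Still open, from the compounds shown here alone, is where a plain pentyl chain, or a pentyl chain ending in an amine or a carboxylic acid, would fall relative to compound 2 and compound 3.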